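The source may hold more compounds than are shown below. What is called first, only, known or untested is meant among the compounds shown, and "the series" means these compounds.

In a functional assay on the whole organism (strain albino) for inhibition, with Rattus norvegicus as the target, read by paw edema, with stated times of 30 min and 2 h, at a dose of 100 mg/kg by the oral route (a lower number here means less inhibition, a higher number more inhibition at the dose given (going by the name of the read-out)), compound 1, with the structure `O=C(CBr)Nc1ccc(C(=O)/C=C/c2ccc(Cl)cc2)cc1`, gives 52%. Compound 2, with the structure `COc1ccc(/C=C/C(=O)c2ccc(NC(=O)CBr)cc2)cc1`, gives 42%, and compound 3, with the structure `CC(Br)C(=O)Nc1ccc(C(=O)/C=C/c2ccc(Cl)cc2)cc1`, gives 45%. Among these three numbers compound 2 holds the lowest, but the gap to compound 3 and the gap to compound 1 both lie within the scatter of repeated measurements, so no order among them can be claimed.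

Compound 4 has the structure `COc1ccc(/C=C/C(=O)c2ccc(NC(=O)C(C)O[N+](=O)[O-])cc2)cc1`. It differs from compound 2 in one place: 1-(nitrooxy)ethyl in place of bromomethyl on a carbonyl carbon. For the measured compounds named here, one measured step touches the same carbonyl carbon: the change a number 7 percentage points lower from compound 1 to compound 3 (within the scatter). The other measured step, a number 10 percentage points lower from compound 1 to compound 2 (within the scatter), concerns a different part of the shared core. Going by the values given here, no measured pair exchanges the bromomethyl group for a 1-(nitrooxy)ethyl group, so the data give no direct guide to its size.

Among the compounds with values here, because the only change at this carbon, a number 7 percentage points lower from compound 1 to compound 3 (within the scatter), stayed within the scatter, compound 4 is expected to show no step beyond the scatter, no change at the digits printed from compound 2 to compound 4 (within the scatter). The estimate for compound 4 is 42%, with a range from 25% to 60%.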

Compound 4, a percentage reported as inhibition, in the whole organism at one dose (the size of the read-out at that dose, not a potency): 46%
The estimate for compound 4 lay 4 percentage points below the measured number; measured number inside the range.
By their numbers in this assay, from the lowest: compounds 2, 3, 4 and 1 (each within the scatter of the next).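

In this assay, replacing bromomethyl on this carbonyl carbon with 1-(nitrooxy)ethyl gives a number 4 percentage points higher from compound 2 to compound 4 (within the scatter). The earlier compounds shown here kept the bromine at this place, changing only a hydrogen to a methyl, whereas compound 4 has no bromine and carries a larger group with hydrogen-bond acceptors, yet its reading at this single dose stays within the scatter of that of compound 2. No measurement shown here explains this result. The exchange also alters two things at once, so the compounds shown do not separate the added branching methyl from the nitrooxy group, a question that unbranched nitrooxymethyl would address. Also open, as far as these compounds go, is how this carbonyl position would respond to a group of a different kind, such as an amine or a carboxylic acid.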